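Lengthening the Chain of Compound 3

The source may hold more compounds than are shown below. What is called first, only, known or untested is meant among the compounds shown, and "the series" means these compounds.

In a functional assay on HCT-116 cells (Homo sapiens) for inhibition, read by MTT assay, with a stated time of 72 h (on this read-out lower numbers stand for stronger inhibition and higher numbers for weaker inhibition), compound 3 (`O=C(CCCCCN(Cc1ccc(F)cc1)c1ncc(C(=O)NCCCn2ccnc2)s1)NO`) gives 19000 nM. Compound 2 (`CC(C)CCN(CCCCCCC(=O)NO)c1ncc(C(=O)NCCCn2ccnc2)s1`) gives 30000 nM, which lies within the usual scatter of compound 3. Compound 1 (`O=C(/C=C/c1ccc(CN(Cc2ccc(F)cc2)c2ncc(C(=O)NCCCn3ccnc3)s2)cc1)NO`) gives 83000 nM, and the difference is a 4.4-fold lower number from compound 1 to compound 3 (0.64 log units; beyond the scatter). That step replaces 4-(2-(hydroxycarbamoyl)ethenyl)phenyl with 4-(hydroxycarbamoyl)butyl, a much larger change than the next one.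

Compound 4 (`O=C(CCCCCCN(Cc1ccc(F)cc1)c1ncc(C(=O)NCCCn2ccnc2)s1)NO`) differs from compound 3 by (hydroxycarbamoyl)methyl in place of hydroxycarbamoyl on a saturated chain carbon, five bonds along the chain from a nitrogen on an aromatic ring. In words, (hydroxycarbamoyl)methyl stands in place of hydroxycarbamoyl on a saturated chain carbon, five bonds along the chain from a nitrogen on an aromatic ring. The chain simply grows longer, with the same end group.

Going by the values given here, no measured step isolates this change, so the modest step above offers only a loose upper guide to its size. The expectation is therefore a 1.1-fold lower number from compound 3 to compound 4 (0.05 log units; within the scatter), with no clear direction and nothing beyond the scatter. For compound 4 the estimated value is 17000 nM, with an expected range of 6000 nM to 45000 nM.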

Compound 4, half-maximal inhibitory concentration: 9700 nM
For compound 4 the middle estimate is 1.8-fold (0.24 log units) above the measured one; the range from low to high includes it.
By their numbers in this assay, from the lowest: compounds 4, 3 and 2 (each within the scatter of the next, the first and the last beyond it); then compound 1.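

In this assay, the step with (hydroxycarbamoyl)methyl in place of hydroxycarbamoyl (a 2.0-fold lower number from compound 3 to compound 4 (0.29 log units; within the scatter)) stays within the scatter, so this one added carbon cannot be read as a real change, and the position accepts the longer chain with no measurable loss. With that chain in place, compound 4 also allows a comparison of the other group on the chain carbon bound to the nitrogen: 4-fluorophenyl in place of isobutyl gives a step beyond the scatter (a 3.1-fold lower number from compound 2 to compound 4 (0.49 log units; beyond the scatter)). The largest step comes with 5-(hydroxycarbamoyl)pentyl in place of 4-(2-(hydroxycarbamoyl)ethenyl)phenyl (an 8.6-fold lower number from compound 1 to compound 4 (0.93 log units; beyond the scatter)).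

Still open, on these data alone, is how a longer chain, such as 6-(hydroxycarbamoyl)hexyl, or a carboxylic acid in place of the hydroxycarbamoyl end would read. Nothing available here explains any of these differences.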